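A few compounds are considered here, and "the series" means these few. Any claim that something is new, unique, unknown or untested is made for them only; others in the source may bear on it.

Measured so far in a functional assay on A-431 cells (Homo sapiens) for antiproliferative activity, read by sulforhodamine B assay, with a stated time of 72 h; on this read-out lower numbers stand for stronger inhibition and higher numbers for weaker inhibition:
compound 1 `C/C=C/C(=O)Nc1cc(Nc2nccc(-c3cn(C)c4ccccc34)n2)c(OC)cc1N(C)CCN(C)C`: 5790 nM
compound 2 `C=C(C(=O)Nc1cc(Nc2nccc(-c3cn(C)c4ccccc34)n2)c(OC)cc1N(C)CCN(C)C)C(F)(F)F`: 11200 nM
compound 3 `C=C(F)C(=O)Nc1cc(Nc2nccc(-c3cn(C)c4ccccc34)n2)c(OC)cc1N(C)CCN(C)C`: 2500 nM

Compound 3 has the lowest number of the three, and its steps to the other two lie beyond the scatter. Next in line is compound 4 `C=C(Br)C(=O)Nc1cc(Nc2nccc(-c3cn(C)c4ccccc34)n2)c(OC)cc1N(C)CCN(C)C`, with the change bromo in place of fluoro on a double-bonded chain carbon bound to a carbonyl carbon. Going by the values given here, no bromo compound has been measured, so no step shows this exchange directly. The closest evidence comes from changes at the same place. These are a 2.3-fold lower number from compound 1 to compound 3 (0.36 log units; beyond the scatter) and a 4.5-fold lower number from compound 2 to compound 3 (0.65 log units; beyond the scatter), both modest, and a 1.9-fold higher number from compound 1 to compound 2 (0.29 log units; within the scatter), within the scatter. With only modest steps seen at this place, a large shift is not expected, and the best guess in this assay is no change beyond the scatter, in either direction. The expected step is a 1.1-fold lower number from compound 3 to compound 4 (0.06 log units; within the scatter). For compound 4 the estimated value is 2200 nM, with an expected range of 800 nM to 6500 nM.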

Compound 4, half-maximal inhibitory concentration: 1060 nM
Beside the measured number, compound 4's estimate is 2.1-fold (0.32 log units) above it; measured number inside the range.
By their numbers in this assay, from the lowest: compound 4; then compound 3; then compounds 1 and 2 (each within the scatter of the next).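

In this assay, going by these compounds alone, the place on a double-bonded chain carbon bound to a carbonyl carbon proves sensitive to the choice of halogen: bromo in place of fluoro gives a 2.4-fold lower number from compound 3 to compound 4 (0.37 log units; beyond the scatter) and so lies beyond the scatter, an exchange the earlier compounds did not cover. Bromo in place of trifluoromethyl gives an 11-fold lower number from compound 2 to compound 4 (1.02 log units; beyond the scatter) and is the first large step at this place, while 1-bromoethenyl in place of prop-1-en-1-yl gives a 5.5-fold lower number from compound 1 to compound 4 (0.74 log units; beyond the scatter) on the same core. Nothing measured here bears on why the numbers fall in this order.

Chloro and iodo at this place remain open, so the series does not show whether the number keeps falling beyond these two halogens. Also open, going by these compounds, is how a dimethylaminomethyl group on the same double-bonded chain carbon would compare with bromo.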